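The compounds below may be only part of what the source reports. "The series", "measured", "known", "first", "only" and "open" are said of these compounds alone.

Measured so far:
compound 1, `Cc1cc(C(=O)O)nn1Cc1cc(Br)ccc1OCc1ccc(F)cc1F`: 2.63 nM
compound 2, `Cc1cc(C(=O)O)nn1Cc1cc(F)ccc1OCc1ccc(Cl)cc1Cl`: 20.4 nM

Both numbers come from a functional assay on CHO-K1 cells for antagonist activity at prostaglandin E2 receptor EP1 subtype (Homo sapiens), read by FLIPR; a lower number here means a stronger inhibitor, a higher number a weaker inhibitor. Of the two, compound 2 holds the higher value, and its gap to compound 1 lies beyond the usual scatter. Within the data shown here, the two measured compounds differ from each other in two places at once, so no single step between measured compounds can be read off, and neither change can be given its own weight.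

Compound 3, `Cc1cc(C(=O)O)nn1Cc1cc(F)ccc1OCc1ccc(F)cc1F`, is not yet measured. It differs from compound 2 in one place only: 2,4-difluorophenyl in place of 2,4-dichlorophenyl on a saturated chain carbon bound to an oxygen on an aromatic ring. Compound 3 therefore carries the 2,4-difluorophenyl group that compound 1 also carries, while the rest of the molecule stays as in compound 2. Among the measured compounds shown here, the only guide is that compound 1, with the 2,4-difluorophenyl group, gives the lower of the two measured values, but that comparison also contains a second change, so it is a weak guide. The expected step is a 2.6-fold lower number from compound 2 to compound 3 (0.41 log units; beyond the scatter), toward a lower number and somewhat beyond the scatter. Compound 3 is expected to give about 8 nM, with a range from 2.5 nM to 25 nM.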

Compound 3, inhibition constant: 7.94 nM
Beside the measured number, compound 3's estimate is 1.0-fold (0.00 log units) above it, within the range that was stated.
By their numbers in this assay, from the lowest: compound 1; then compound 3; then compound 2.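

In this assay, the two changes mixed together in the comparison of compound 1 with compound 2 can now be read apart, each as a single step beyond the scatter. On a saturated chain carbon bound to an oxygen on an aromatic ring, 2,4-difluorophenyl in place of 2,4-dichlorophenyl gives a 2.6-fold lower number from compound 2 to compound 3 (0.41 log units; beyond the scatter) and so has a modest effect of its own, while fluoro in place of bromo on an aromatic carbon gives a 3.0-fold higher number from compound 1 to compound 3 (0.48 log units; beyond the scatter) and so runs the opposite way. Entry of fluorine therefore has no single direction across these two places, and no measurement here bears on the cause of either step.

From the compounds shown here alone, whether the two steps hold independently of each other remains open, since each has been read against only one setting of the other place. Also open, going by these compounds, is how far the aromatic carbon that carries bromo in compound 1 tolerates other groups, such as chloro, methoxy or trifluoromethyl, and whether a 2,4-dibromophenyl group on the chain carbon continues the trend from 2,4-difluorophenyl and 2,4-dichlorophenyl.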